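A few compounds are considered here, and "the series" means these few. Any claim that something is new, unique, unknown or untested is made for them only; others in the source may bear on it.

Compounds measured in an ADME assay on MDCK cells (Canis lupus familiaris) for cytotoxicity, read by microscopy, with a stated time of 48 h (a higher number here means that more compound is tolerated, a lower number that less compound is tolerated), so far:

Compound 1, `C[C@H]1[C@H](NCc2ccsc2)C[C@H]2C[C@@H]1C2(C)C`: 50000 nM
Compound 2, `C[C@H]1[C@H](NCc2sccc2Br)C[C@H]2C[C@@H]1C2(C)C`: 50000 nM
Compound 3, `Cc1ccsc1CN[C@@H]1C[C@H]2C[C@@H]([C@H]1C)C2(C)C`: 10000 nM

Compound 3 holds the lowest of the three numbers in this assay, with the steps of a 5.0-fold lower number from compound 1 to compound 3 (0.70 log units; beyond the scatter) and a 5.0-fold lower number from compound 2 to compound 3 (0.70 log units; beyond the scatter) both lying beyond the scatter. The shared core is kept in every case; only the aromatic group on the saturated chain carbon bound to the amine nitrogen changes. Compound 4, `Cc1csc(CN[C@@H]2C[C@H]3C[C@@H]([C@H]2C)C3(C)C)n1`, continues this with 4-methyl-1,3-thiazol-2-yl in place of 3-methylthiophen-2-yl on a saturated chain carbon bound to an amine nitrogen.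

Both measured steps toward compound 3 exchanged an aromatic group at the same position and each gave a modest lowering. Within the data shown here, the step to compound 4 is likewise an aromatic exchange, but no measured step involves a 4-methyl-1,3-thiazol-2-yl group, so the direction is uncertain. Compound 4 is therefore expected to give 25000 nM, between 10000 nM and 50000 nM, a step of a 2.5-fold higher number from compound 3 to compound 4 (0.40 log units; beyond the scatter).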

Compound 4, minimum cytotoxic concentration: > 100000 nM
Compound 4 ended at the assay's limit; the forecaster's own chance of this, stated with the estimate: 10%; middle value at least 4.0-fold (0.60 log units) away from the limit.
By their numbers in this assay, from the lowest: compound 3; then compounds 1 and 2 (each within the scatter of the next). At a limit, above all of these: compound 4.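

In this assay compound 4 stands at a limit, not at a number: the limit of > 100000 nM in this assay, at which 1 of the 4 values shown sits. On a saturated chain carbon bound to an amine nitrogen, the exchange of 3-methylthiophen-2-yl for 4-methyl-1,3-thiazol-2-yl reverses the lowering seen so far and gives an at least 10-fold higher number from compound 3 to compound 4 (1.00 log units; beyond the scatter). Against the other two thiophene compounds the reading is weaker, with an at least 2.0-fold higher number from compound 2 to compound 4 (0.30 log units; that floor lies within the scatter) and an at least 2.0-fold higher number from compound 1 to compound 4 (0.30 log units; that floor lies within the scatter). The compounds shown leave open how far compound 4 lies past its limit, and whether a 1,3-thiazol-2-yl group without the methyl, or a pyridin-2-yl group, would reach that limit too.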